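Aryl group on the ring amine: compound 3 to compound 4

The source may report more compounds than this note shows. Statements on the series, on what has been measured and on what is new or still open speak of the compounds shown alone.

Compound 3 `CCCc1nc(-c2ccccc2)c(CNCCCN2CCN(c3ccccc3Cl)CC2)o1` gives 64.7% in an assay on HEK293 cells for inhibition of Voltage-dependent T-type calcium channel subunit alpha-1G (Homo sapiens), read by fluorescence, tested at 10 uM (on this read-out lower numbers stand for less inhibition and higher numbers for more inhibition at the one concentration tested (going by the name of the read-out)), and sits at the top of the three numbers recorded, though not separated from compound 2 beyond the scatter. Compound 2 `CCCc1nc(-c2ccccc2)c(CNCCCN2CCN(c3ccc(F)cc3)CC2)o1` gives 62.5% in this assay, and compound 1 `CCCc1nc(-c2ccccc2)c(CNCCCN2CCN(c3cccc(OC)c3)CC2)o1` gives 36.4%. The two steps away from compound 1 are a number 26.1 percentage points higher from compound 1 to compound 2 (beyond the scatter) and a number 28.3 percentage points higher from compound 1 to compound 3 (beyond the scatter); the step between the two higher compounds is a number 2.2 percentage points higher from compound 2 to compound 3 (within the scatter).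

Compound 4 `CCCc1nc(-c2ccccc2)c(CNCCCN2CCN(c3ccc(Cl)cc3)CC2)o1` differs from compound 3 by 4-chlorophenyl in place of 2-chlorophenyl on an amine nitrogen in a ring. Among the measured compounds shown here, the one measured step that bears on this exchange of one halogen-bearing aryl group for another is a number 2.2 percentage points higher from compound 2 to compound 3 (within the scatter); the larger steps of a number 26.1 percentage points higher from compound 1 to compound 2 (beyond the scatter) and a number 28.3 percentage points higher from compound 1 to compound 3 (beyond the scatter) both concern removal of the 3-methoxyphenyl, which compound 4 does not revisit. No step beyond the scatter is therefore expected in this assay. Compound 4 is estimated at 62%, with a range of 45% to 78%. This estimate means an expected step of a number 2.7 percentage points lower from compound 3 to compound 4 (within the scatter).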

Compound 4, a percentage reported as inhibition, at one concentration (the size of the read-out at that concentration, not a potency): 63.3%
For compound 4 the middle estimate is 1.3 percentage points below the measured one, within the range that was stated.
By their numbers in this assay, from the lowest: compound 1; then compounds 2, 4 and 3 (each within the scatter of the next).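

The exchange of 2-chlorophenyl for 4-chlorophenyl gives a number 1.4 percentage points lower from compound 3 to compound 4 (within the scatter), so in this assay the place of the chlorine on this aryl group does not separate this pair. Chloro in place of fluoro on an aromatic carbon gives a number 0.8 percentage points higher from compound 2 to compound 4 (within the scatter), the first comparison of two halogens with the aryl position held the same, and it does not separate them either. The exchange of 3-methoxyphenyl for 4-chlorophenyl gives a number 26.9 percentage points higher from compound 1 to compound 4 (beyond the scatter), so all three halogen-bearing aryl groups shown stand beyond the scatter from the 3-methoxyphenyl.

No measurement here accounts for the gap to compound 1. From the compounds shown here alone, whether that gap follows the methoxy group or its place on the aryl ring stays open, and 4-methoxyphenyl or unsubstituted phenyl on the same ring nitrogen would bear on it.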